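A few compounds are considered here, and "the series" means these few. Any claim that something is new, unique, unknown or untested is made for them only; others in the source may bear on it.

In an ADME assay on HEK293 cells (Homo sapiens) for cytotoxicity, with a stated time of 72 h (on this read-out lower numbers stand for an effect already at smaller amounts and higher numbers for an effect only at larger amounts of compound), the three measured ureas all rest at the limit of the measurement. Compound 1, `Cc1ccc(NC(=O)Nc2cc(C)nc3ccccc23)cc1`, gives > 25000 nM in this assay, which is a limit rather than a number. Compound 2, `Cc1cc(NC(=O)Nc2ccc(Cl)cc2)c2ccccc2n1`, gives > 25000 nM in this assay, again a limit. Compound 3, `Cc1cc(NC(=O)Nc2ccccc2OC(F)(F)F)c2ccccc2n1`, gives > 25000 nM in this assay, also a limit. For the measured compounds named here, the one step between measured compounds that differ in a single place, a step that the two limits leave unreadable from compound 1 to compound 2, is thus unreadable, both of its ends being limits; the only evidence on the measured values is the limit of > 25000 nM in this assay, at which 3 of the 3 values shown sit.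

Compound 4, `Cc1cc(NC(=O)Nc2ccccc2N)c2ccccc2n1`, differs from compound 3 by amino in place of trifluoromethoxy on an aromatic carbon. Going by the values given here, no measured step bears on this change in a readable way: the step from compound 1 to compound 2 has no size, and compound 3 itself is known only as a limit. Because all three values shown sit at the limit of > 25000 nM in this assay, at which 3 of the 3 values shown sit, compound 4 is expected to show no step beyond the scatter in this assay and most likely to return a limit as well. Compound 4 is estimated at 40000 nM, within 15000 nM to 120000 nM. The step this estimate means, a step that the limit leaves unreadable from compound 3 to compound 4, is expected to be small.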

Compound 4, half-maximal effective concentration: > 25000 nM
Compound 4 was reported as a limit; the forecaster's own chance of this, stated with the estimate: 80%; the middle value is on the limit's open side.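

In this assay compound 4 gives > 25000 nM, which is a limit. Its steps from compound 1, compound 2 and compound 3 have limits at both ends and cannot be read. The compounds shown leave open whether any change among them alters this read-out, and where their actual values lie: the limit of > 25000 nM in this assay, at which 4 of the 4 values shown sit.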